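From compound 3 to compound 4: a piperazin-1-yl exchange

The source may hold more compounds than are shown below. What is called first, only, known or untested is meant among the compounds shown, and "the series" means these compounds.

Of the compounds shown here, three sharing one core have been measured in a functional assay on GOTO cells (Homo sapiens) for cytotoxicity, read by MTT assay, with a stated time of 3 days; a higher number here means a weaker inhibitor, a lower number a stronger inhibitor. Compound 1 `N#Cc1c(Cl)nc(SCc2nc3ccccc3[nH]2)nc1-c1ccccc1`, which carries chloro, gives 8.62 nM. Compound 2 `CNc1nc(SCc2nc3ccccc3[nH]2)nc(-c2ccccc2)c1C#N`, with methylamino in its place, gives 3.28 nM. Compound 3 `N#Cc1c(NNC(N)=S)nc(SCc2nc3ccccc3[nH]2)nc1-c1ccccc1` gives 2.55 nM, so it stands with compound 2 at the low end of the three numbers and clear of compound 1.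

Compound 4 `N#Cc1c(-c2ccccc2)nc(SCc2nc3ccccc3[nH]2)nc1N1CCNCC1` departs from compound 3 on the same aromatic carbon: a group of 6 heavy atoms (4 carbon, 2 nitrogen; one six-membered non-aromatic ring with 2 hetero atoms) in place of a group of 5 heavy atoms (1 carbon, 3 nitrogen, 1 sulfur; no ring), on an aromatic carbon. Two measured exchanges of the chlorine bear on this, and both are modest: a 2.6-fold lower number from compound 1 to compound 2 (0.42 log units; beyond the scatter) and a 3.4-fold lower number from compound 1 to compound 3 (0.53 log units; beyond the scatter). The closest guide is the exchange between the two nitrogen-linked groups, a 1.3-fold lower number from compound 2 to compound 3 (0.11 log units; within the scatter), which stays within the scatter. Piperazin-1-yl is also attached through nitrogen, so compound 4 is expected to stay near compound 3 and compound 2 in this assay. Among the compounds with values here, no measured compound has a ring at this position, which leaves the range wide.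

The expected change is a 1.2-fold higher number from compound 3 to compound 4 (0.07 log units; within the scatter), which is not expected to lie beyond the scatter. Compound 4 is estimated at 3 nM, with an expected range of 1.3 nM to 7.5 nM.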

Compound 4, half-maximal inhibitory concentration: 3.7 nM
Estimate against measurement, compound 4: 1.2-fold (0.09 log units) below; measured number inside the range.
By their numbers in this assay, from the lowest: compounds 3, 2 and 4 (each within the scatter of the next); then compound 1.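

In this assay, piperazin-1-yl brings the first ring to this position, and the change from chloro still lowers the number beyond the scatter (a 2.3-fold lower number from compound 1 to compound 4 (0.37 log units; beyond the scatter)), a modest step. The ring also stays within the scatter of both open-chain groups (a 1.1-fold higher number from compound 2 to compound 4 (0.05 log units; within the scatter); a 1.5-fold higher number from compound 3 to compound 4 (0.16 log units; within the scatter)), so across compounds 2, 3 and 4 this position accepts a six-membered non-aromatic ring with 2 hetero atoms, and the drop from 3 hydrogen-bond donors in the group of compound 3 to 1 hydrogen-bond donor in piperazin-1-yl gives no step beyond the scatter. No measurement on hand accounts for why these three groups sit together below compound 1.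

The compounds shown leave open whether the second ring nitrogen of piperazin-1-yl matters, which morpholin-4-yl or 4-methylpiperazin-1-yl at the same carbon would address. They also leave open whether attachment through nitrogen is needed at all, since every group here that gives a lower number than chloro is linked that way, and a methoxy group or a directly attached carbon chain would test that.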